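The source may report more compounds than this note shows. Statements on the series, on what has been measured and on what is new or still open speak of the compounds shown alone.

Measured compounds in a functional assay on HeLa cells (Homo sapiens) for inhibition, read by MTT assay; on this read-out higher numbers stand for weaker inhibition and lower numbers for stronger inhibition:
- compound 1 `CCCCCCCCn1cc(/C=C/C(=O)c2ccc(NC(=O)CN3CCN(c4ccccc4)CC3)cc2)nn1` — 33800 nM
- compound 2 `CCCCCCCCn1cc(/C=C/C(=O)c2ccc(NC(=O)CN3CCN(C(=O)OC(C)(C)C)CC3)cc2)nn1` — 32100 nM

Compound 2 gives the lowest of the two numbers in this assay, but its nearest neighbour, compound 1, lies within the scatter, so the two compounds cannot be told apart. Compound 3 `CCCCCCCCn1cc(/C=C/C(=O)c2ccc(NC(=O)CN3CCN(c4ccc([N+](=O)[O-])cc4)CC3)cc2)nn1` has not yet been measured. It differs from compound 2 in one place: 4-nitrophenyl in place of tert-butoxycarbonyl on an amine nitrogen in a ring. Among the measured compounds shown here, one measured step bears on this exchange: a 1.1-fold lower number from compound 1 to compound 2 (0.02 log units; within the scatter), where a phenyl gave way to a tert-butoxycarbonyl on an amine nitrogen in a ring. Compound 3 brings a phenyl ring back to that nitrogen, now bearing a nitro group, and nothing in the measured pair shows such a group shifting the number. The expected step is therefore a 1.0-fold higher number from compound 2 to compound 3 (0.01 log units; within the scatter), nothing beyond the scatter. Compound 3 is estimated at 33000 nM, with a range from 15000 nM to 70000 nM.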

Compound 3, half-maximal inhibitory concentration: 30200 nM
Compound 3: middle estimate off by 1.1-fold (0.04 log units), on the high side; the range from low to high includes it.
By their numbers in this assay, from the lowest: compounds 3, 2 and 1 (each within the scatter of the next).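

In this assay, replacing tert-butoxycarbonyl with 4-nitrophenyl on the amine nitrogen in the ring gives a 1.1-fold lower number from compound 2 to compound 3 (0.03 log units; within the scatter), and placing a nitro group on the phenyl ring gives a 1.1-fold lower number from compound 1 to compound 3 (0.05 log units; within the scatter). Both steps lie within the scatter, so a nitro group on the phenyl ring, which the earlier pair did not test, produces no change that can be read, and the three groups now tried on this nitrogen cannot be told apart in this assay. No supporting measurement is available to explain this flat result.

The compounds shown leave open whether a bare hydrogen on this nitrogen, or a group carrying a carboxylic acid or a free amine, would move the number beyond the scatter. They also leave open whether a methoxy group or a chlorine on the phenyl ring would do so.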